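This account rests on a few compounds, and the source may have more. Where it says the series, first, only, none or still open, it means among the compounds named here.

Compound 1 `Cc1ccnc(/C(N)=N/NC(=S)N2CCSCC2)c1` and compound 2 `Cc1cccc(/C(N)=N/NC(=S)N2CCCCC2)n1` share the same core and have both been run in a functional assay on A-375 cells (Homo sapiens) for cytotoxicity, read by MTT assay, with a stated time of 72 h, tested at 30 uM; a higher number here means more inhibition of growth at the concentration tested, a lower number less inhibition of growth. In this assay compound 1 gives 84.9%, and compound 2 gives 80.9%. Compound 1 holds the higher of the two numbers, but its gap to compound 2 lies within the scatter, so the two values read as indistinguishable. Among the compounds with values here, the two compounds differ from each other in more than one place, so no single step between them can be drawn; the pair shows only that both reach a high degree of growth inhibition at the concentration used.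

Compound 3 `Cc1ccnc(/C(N)=N/NC(=S)N2CCOCC2)c1` has not yet been measured. Relative to compound 1 the change is morpholin-4-yl in place of thiomorpholin-4-yl on a thiocarbonyl carbon. Nothing in the measured pair bears on this exchange, so the expectation rests on the high level that compound 1 shows at 84.9%. The expected step, a number 6.9 percentage points lower from compound 1 to compound 3 (within the scatter), is small and downward and may well stay within the scatter. For compound 3 in this assay the estimate is 78%, with a range from 55% to 92%.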

Compound 3, percent growth inhibition at one concentration: 87.4%
Beside the measured number, compound 3's estimate is 9.4 percentage points below it; the measured number falls inside the stated range.
By their numbers in this assay, from the lowest: compounds 2, 1 and 3 (each within the scatter of the next).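

Within the data shown here, at the thiocarbonyl carbon, the exchange of thiomorpholin-4-yl for morpholin-4-yl gives the first comparison that differs in one place: in this assay the step is a number 2.5 percentage points higher from compound 1 to compound 3 (within the scatter) and so gives no readable separation between the two rings. On the shared core of compound 1, the ring sulfur can therefore give way to oxygen without a measurable change in growth inhibition at the concentration tested, so the two groups cannot be told apart at this position in this assay. No measured evidence is available to explain this outcome.

From the compounds shown here alone, whether this tolerance extends to a piperazin-1-yl ring or to an open-chain group such as dimethylamino on the same thiocarbonyl carbon remains open. Going by these compounds, since all three compounds stand within the scatter of their nearest neighbours at a single concentration, it also remains open whether compound 1 and compound 3 would separate in a full concentration series.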